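Trifluoromethoxy in place of phenoxy on a fluoroallylamine

The source may hold more compounds than are shown below. What is called first, only, known or untested is meant among the compounds shown, and "the series" means these compounds.

Compound 1 `NC/C=C\COc1ccccc1`: > 100000 nM
Compound 2 `NC/C=C(/F)COc1ccc(Oc2ccccc2)cc1`: 240 nM

Of the compounds shown here, two have been measured in an assay on isolated protein for inhibition of Amine oxidase [copper-containing] 3 (Homo sapiens), read by Amplex Red; on this read-out higher numbers stand for weaker inhibition and lower numbers for stronger inhibition. For compound 1 `NC/C=C\COc1ccccc1` the result is a limit of the assay, not a number: > 100000 nM, as recorded in the limit of > 100000 nM in this assay, at which 1 of the 2 values shown sits. Compound 2 `NC/C=C(/F)COc1ccc(Oc2ccccc2)cc1` gives 240 nM in this assay, the only actual number shown. Since the pair differs in more than one place, no single step between them is defined, and only their two values are shown.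

Compound 3 `NC/C=C(/F)COc1ccc(OC(F)(F)F)cc1` has not yet been measured. It differs from compound 2 by trifluoromethyl in place of phenyl on an oxygen on an aromatic ring. Both groups sit on the same oxygen, and neither carries a hydrogen-bond donor or acceptor. Within the data shown here, no measured step of this kind is available to lean on, so the size of the change is uncertain; a modest loss, or a step within the scatter, is expected.

For compound 3 the expected value in this assay is 450 nM, with a range from 100 nM to 2500 nM, which means an expected step of a 1.9-fold higher number from compound 2 to compound 3 (0.27 log units; within the scatter).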

Compound 3, half-maximal inhibitory concentration: 180 nM
Compound 3: the middle estimate sits 2.5-fold (0.40 log units) above what was measured; the measured number falls inside the stated range.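

In this assay, replacing phenyl with trifluoromethyl on the oxygen gives a 1.3-fold lower number from compound 2 to compound 3 (0.12 log units; within the scatter), so compound 2 and compound 3 cannot be told apart in this assay. Among these compounds, this is the first direct comparison at this position, and it shows that the outer aromatic ring of compound 2 is not required for this level of inhibition: a group with no ring and fewer heavy atoms serves equally well here. The two groups differ greatly in shape and atom makeup, yet nothing measured here explains why they give matching results.

Compound 1 gives > 100000 nM, which is a limit of the assay, and it differs from compound 2 and compound 3 both in lacking the fluorine on the chain and in lacking any group on the aromatic ring, so its result cannot be assigned to either difference alone. As far as these compounds go, it also remains open whether this position would accept an amine, a carboxylic acid or a longer chain such as butyl, or whether the fluorine could be replaced by a chlorine without a loss of inhibition.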